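From compound 3 to compound 4: a ring swap

A few compounds are considered here, and "the series" means these few. Any claim that something is new, unique, unknown or untested is made for them only; others in the source may bear on it.

Measured in an in vitro ADME assay on microsomes from liver (Mus musculus) for pharmacokinetics, read by LC-MS, with a stated time of 10 min, tested at 1 uM; on this read-out higher numbers stand for fast clearance and lower numbers for slow clearance:
Compound 1 `CC(C)c1ccc(NC(=O)[C@H]2CN(C)C[C@@H]2c2ccc(/C=C/C(=O)Nc3ccccc3N)cc2)cc1`: 54 mL/min/kg
Compound 2 `COc1cccc(NC(=O)[C@H]2CN(C)C[C@@H]2c2ccc(/C=C/C(=O)Nc3ccccc3N)cc2)c1`: 65 mL/min/kg
Compound 3 `Cc1cc(NC(=O)[C@H]2CN(C)C[C@@H]2c2ccc(/C=C/C(=O)Nc3ccccc3N)cc2)ccc1F`: 62 mL/min/kg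

Compound 3, at 62 mL/min/kg, cannot be told apart from the other two compounds. Its steps, a 1.1-fold higher number from compound 1 to compound 3 (0.06 log units; within the scatter) and a 1.0-fold lower number from compound 2 to compound 3 (0.02 log units; within the scatter), both lie within the scatter.

Compound 4 `Cc1ccc(NC(=O)[C@H]2CN(C)C[C@@H]2c2ccc(/C=C/C(=O)Nc3ccccc3N)cc2)cn1` differs from compound 3 in one place: 6-methylpyridin-3-yl in place of 4-fluoro-3-methylphenyl on an amide-type nitrogen. In words, 6-methylpyridin-3-yl stands in place of 4-fluoro-3-methylphenyl on an amide-type nitrogen.

The measured steps all changed the group at this same place. Besides the two above, there is a 1.2-fold higher number from compound 1 to compound 2 (0.08 log units; within the scatter), also within the scatter. None of them introduces a ring with a hetero atom, so they are only indirect guides to this change.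

On the strength of these small steps, no step beyond the scatter is expected in this assay. The expected step is a 1.2-fold lower number from compound 3 to compound 4 (0.07 log units; within the scatter), and its direction remains uncertain. For compound 4 the estimated clearance is 53 mL/min/kg, with an expected range from 32 mL/min/kg to 78 mL/min/kg.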

Compound 4, clearance: 57 mL/min/kg
For compound 4 the middle estimate is 1.1-fold (0.03 log units) below the measured one; the range from low to high includes it.
By their numbers in this assay, from the lowest: compounds 1, 4, 3 and 2 (each within the scatter of the next).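

For the compounds shown here, putting a ring with a hetero atom on this amide-type nitrogen, which none of the earlier compounds did, produces no step beyond the scatter in this assay: a 1.1-fold lower number from compound 3 to compound 4 (0.04 log units; within the scatter), a 1.1-fold lower number from compound 2 to compound 4 (0.06 log units; within the scatter) and a 1.1-fold higher number from compound 1 to compound 4 (0.02 log units; within the scatter). The clearance numbers of all the compounds shown therefore cannot be told apart, even though 6-methylpyridin-3-yl counts a hydrogen-bond acceptor where 4-fluoro-3-methylphenyl counts none. No measurement at hand gives a reason for this flat result.

All the compounds shown carry a six-membered aromatic ring at this place, so they leave open how a saturated amine such as piperidinyl or a plain alkyl chain on this nitrogen would read. They also leave open what a change elsewhere would do, as the rest of the structure is the same throughout.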